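The compounds below may be only part of what the source reports. "The series", "measured", "known", "first", "only" and "open" are said of these compounds alone.

Of the compounds shown here, three have numbers so far in a functional assay on CCRF-CEM cells (Homo sapiens) for antiproliferative activity; a higher number here means a weaker inhibitor of growth, a lower number a stronger inhibitor of growth. Compound 1 (`CCCCCCNC(=O)c1cc(CCc2cc(O)ccc2O)ccc1O`) gives 5100 nM there, and compound 3 (`CCCCCCNC(=O)c1cc(/C=C\c2cc(O)ccc2O)ccc1O`) gives 1200 nM there. Compound 2 (`CCCCCCNC(=O)c1cc(C#Cc2cc(OC)ccc2OC)ccc1OC`) gives 7900 nM there, a number within the scatter of compound 1 but beyond the scatter of compound 3, on the weaker side. Compound 4 (`COC(=O)c1cc(C#Cc2cc(OC)ccc2OC)ccc1OC`) differs from compound 2 by methoxy in place of hexylamino on a carbonyl carbon. Within the data shown here, no measured pair shows this change alone, so the data do not size it. A modest move toward a higher number is expected in this assay here, perhaps none beyond the scatter. The estimated change is small (a 1.3-fold higher number from compound 2 to compound 4 (0.10 log units; within the scatter)). Compound 4 is expected to give about 10000 nM (estimated range 3000 nM to 35000 nM).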

Compound 4, concentration for 50% growth inhibition: 36800 nM
The estimate for compound 4 lay 3.7-fold (0.57 log units) below the measured number; the measured number lies above the stated range.
By their numbers in this assay, from the lowest: compound 3; then compounds 1 and 2 (each within the scatter of the next); then compound 4.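

In this assay, methoxy in place of hexylamino on a carbonyl carbon, which turns hexylcarbamoyl into methoxycarbonyl, gives a 4.7-fold higher number from compound 2 to compound 4 (0.67 log units; beyond the scatter) and so moves the number beyond the scatter. This position is therefore not indifferent to the change, and here the hexylamino group goes with stronger growth inhibition. No measurement offered here gives a reason for this step. The compounds shown leave open whether the shift follows the loss of the hexyl chain, the amide hydrogen or the amide itself, which a methylamino group, a butylamino group or a carboxylic acid on this carbonyl carbon could separate.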